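Hydroxyphenyl swap on two pyridine cores, topoisomerase inhibition

The source may hold more compounds than are shown below. What is called first, only, known or untested is meant among the compounds shown, and "the series" means these compounds.

Measured so far:
compound 1 `Oc1cccc(-c2cc(-c3cccs3)cc(-c3ccccc3O)n2)c1`: 83.2%
compound 2 `Oc1cccc(-c2cc(-c3cccs3)cc(-c3cccc(O)c3)n2)c1`: 91.7%
compound 3 `Oc1ccccc1-c1cc(-c2ccoc2)cc(-c2ccccc2O)n1`: 1%

In an assay on isolated protein for inhibition of DNA topoisomerase 1 (Homo sapiens), with a stated time of 30 min, tested at 100 uM (on this read-out lower numbers stand for a weaker effect and higher numbers for a stronger effect at the one concentration tested), compound 1 gives 83.2% and compound 2 gives 91.7%. The two differ in one place, (3-hydroxyphenyl in place of 2-hydroxyphenyl on an aromatic carbon), and the step of a number 8.5 percentage points higher from compound 1 to compound 2 (within the scatter) is small. Compound 3 is built on a different core, and in this assay compound 3 gives 1%, far under both others. The difference between the core of compound 3 and the core of compound 1 is not broken down here.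

Compound 4 `Oc1cccc(-c2cc(-c3ccoc3)cc(-c3ccccc3O)n2)c1` is not yet measured in this assay. It is made from compound 3 by 3-hydroxyphenyl in place of 2-hydroxyphenyl on an aromatic carbon, the same kind of change as from compound 1 to compound 2. The surroundings are not identical: in compound 3 the changed carbon is meta to a 2-hydroxyphenyl group and meta to a furan-3-yl group, whereas in compound 1 it is meta to a 3-hydroxyphenyl group and meta to a thiophen-2-yl group.

Within the data shown here, the expectation rests on the one measured instance: because a number 8.5 percentage points higher from compound 1 to compound 2 (within the scatter) lay within the scatter, the step on the core of compound 3 is also expected to be small, a number 7 percentage points higher from compound 3 to compound 4 (within the scatter), with the added uncertainty that compound 3 sits close to the floor of the read-out. Compound 4 is therefore estimated at 8%, between 0% and 35%.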

Compound 4, a percentage reported as inhibition, at one concentration (the size of the read-out at that concentration, not a potency): 29.5%
Compound 4: the middle estimate sits 21.5 percentage points below what was measured; low and high end bracket the measured number.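

In this assay, 3-hydroxyphenyl in place of 2-hydroxyphenyl does not carry over from one core to the other at a constant size: the same change on two cores in this assay, a number 8.5 percentage points higher (within the scatter) from compound 1 to compound 2 and a number 28.5 percentage points higher (beyond the scatter) from compound 3 to compound 4, 20 percentage points apart, beyond the scatter of two such steps

The change gives a step beyond the scatter only on the furan-3-yl side, a number 28.5 percentage points higher from compound 3 to compound 4 (beyond the scatter), and this does not bring that side level with the thiophen-2-yl side, as furan-3-yl in place of thiophen-2-yl gives a number 53.7 percentage points lower from compound 1 to compound 4 (beyond the scatter). With one pair per core, this shows only that the step is not transferable at a fixed size among these four compounds; it does not show why, and the two pairs differ in more than the five-membered ring, since the group left standing is 3-hydroxyphenyl in compound 1 and 2-hydroxyphenyl in compound 3.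

The compounds shown leave open how the same change reads on the thiophen-2-yl core with a 2-hydroxyphenyl group left standing, and on the furan-3-yl core with a 3-hydroxyphenyl group left standing. They also leave open whether the hydroxyl itself can give way to an amine or a carboxylic acid on either core.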